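A few compounds are considered here, and "the series" means these few. Any claim that something is new, unique, unknown or untested is made for them only; others in the source may bear on it.

Compound 2 `CCCNc1c(C)nc(-c2c(C)cc(C)cc2OC)nc1OC` carries a propylamino group on the shared core. In an in vitro assay on IMR-32 cells for displacement of a labelled ligand from corticotropin-releasing factor receptor 1 (Homo sapiens) (a higher number here means a weaker inhibitor, a lower number a stronger inhibitor), compound 2 reaches only the assay limit, > 10000 nM, so no number is known for it. Compound 1 `CCCN(CCC)c1c(C)nc(-c2c(C)cc(C)cc2OC)nc1OC`, with a second propyl on the same nitrogen, gives 15 nM in this assay. Among the compounds with values here, the only measured step is an at least 660-fold higher number from compound 1 to compound 2 (2.82 log units; beyond the scatter); it ends at the limit of > 10000 nM in this assay, at which 1 of the 2 values shown sits, so its full size is not known.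

Compound 3 `CCC(CC)Nc1c(C)nc(-c2c(C)cc(C)cc2OC)nc1OC` differs from compound 2 by ethyl in place of hydrogen on a saturated chain carbon bound to a nitrogen on an aromatic ring and a saturated chain carbon. This adds carbon back near the nitrogen where the measured step removed a propyl, though on the chain rather than on the nitrogen itself. A move toward lower numbers in this assay is therefore expected, probably not recovering all of the measured loss, and the estimate is wide because compound 2 stands at the limit of > 10000 nM in this assay, at which 1 of the 2 values shown sits.

For compound 3 the expected value in this assay is 150 nM, within 15 nM to 3000 nM. This estimate corresponds to the step of an at least 66-fold lower number from compound 2 to compound 3 (1.82 log units; beyond the scatter).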

Compound 3, inhibition constant: 94 nM
Compound 3: middle estimate off by 1.6-fold (0.20 log units), on the high side, and the stated range covers the measured number.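

With the amine hydrogen kept, ethyl in place of hydrogen on the saturated chain carbon gives an at least 100-fold lower number from compound 2 to compound 3 (2.02 log units; beyond the scatter) in this assay and so shows that this hydrogen on the nitrogen does not by itself rule out strong inhibition. The size of that step is only a lower bound, as compound 2 stands at a limit: the limit of > 10000 nM in this assay, at which 1 of the 3 values shown sits.

Replacing dipropylamino with (pentan-3-yl)amino leaves a 6.3-fold higher number from compound 1 to compound 3 (0.80 log units; beyond the scatter) as a modest gap beyond the scatter, so the added ethyl recovers much of the loss but not all of it.

The compounds shown leave open whether the gain follows the carbon count or the branching at the chain carbon, a question that a straight pentylamino group would address. Also open, going by these compounds, is whether a ring on the nitrogen, such as cyclopentylamino, would match (pentan-3-yl)amino.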